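The source may report more compounds than this note shows. Statements on the series, on what has been measured and on what is new or still open speak of the compounds shown alone.

Of the compounds shown here, three built on a shared core have been tested in a functional assay on A549 cells (Homo sapiens) for inhibition, read by CCK-8 assay, with a stated time of 72 h, tested at 1 uM; on this read-out lower numbers stand for a weaker effect and higher numbers for a stronger effect at the one concentration tested. Compound 1, `CN(C)C(=O)c1cc2cnc(Nc3ccc(S(=O)(=O)NCCCCN=C=S)cc3)nc2n1C1CCCC1`, carries a chain ending in an isothiocyanate; in this assay compound 1 gives 39.4%. Compound 2, `CN(C)C(=O)c1cc2cnc(Nc3ccc(S(=O)(=O)NCCCCCN=C=S)cc3)nc2n1C1CCCC1`, differs from it in one place: a group of 4 heavy atoms (2 carbon, 1 nitrogen, 1 sulfur; no ring) in place of a group of 3 heavy atoms (1 carbon, 1 nitrogen, 1 sulfur; no ring), on a saturated chain carbon, four bonds along the chain from a sulfonamide nitrogen. In this assay compound 2 gives 56.6%. This lengthening of the chain produces a number 17.2 percentage points higher from compound 1 to compound 2 (beyond the scatter). Compound 3, `CN(C)C(=O)c1cc2cnc(Nc3ccc(C(=O)NCCCCCCN=C=S)cc3F)nc2n1C1CCCC1`, rests on a different core, and how that core differs from the core of compound 1 is not broken down here. In this assay compound 3 gives -11.8%, the lowest of the three numbers.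

Compound 4, `CN(C)C(=O)c1cc2cnc(Nc3ccc(C(=O)NCCCCCCCN=C=S)cc3F)nc2n1C1CCCC1`, has not yet been measured. It relates to compound 3 as compound 2 relates to compound 1: a group of 4 heavy atoms (2 carbon, 1 nitrogen, 1 sulfur; no ring) in place of a group of 3 heavy atoms (1 carbon, 1 nitrogen, 1 sulfur; no ring), on a saturated chain carbon, six bonds along the chain from an amide-type nitrogen. For the measured compounds named here, this is the same kind of change as the one from compound 1 to compound 2, but not the same change, since here the place is six bonds along the chain from an amide-type nitrogen rather than four bonds along the chain from a sulfonamide nitrogen.

The expectation for compound 4 rests on compound 1 and compound 2, where the same kind of change gave a number 17.2 percentage points higher from compound 1 to compound 2 (beyond the scatter), and on compound 3 with -11.8%, a low starting point on a different core. For compound 4 the expected step is a number 11.8 percentage points higher from compound 3 to compound 4 (beyond the scatter), somewhat smaller than the measured one. Compound 4 is therefore estimated to reach 0%, most likely lying between -14% and 20%.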

Compound 4, a percentage reported as inhibition, at one concentration (the size of the read-out at that concentration, not a potency): 0.05%
The estimate for compound 4 lay 0.1 percentage points below the measured number; low and high end bracket the measured number.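

In this assay, lengthening the chain that ends in the isothiocyanate gives a number 11.9 percentage points higher from compound 3 to compound 4 (beyond the scatter), so the change moves the number in the same direction on the second core as on the first. Placed side by side, the two steps show that the gain carries over from one core to the other, with no measurable difference in its size: the same change on two cores in this assay, a number 17.2 percentage points higher (beyond the scatter) from compound 1 to compound 2 and a number 11.9 percentage points higher (beyond the scatter) from compound 3 to compound 4, 5.4 percentage points apart, within the scatter of two such steps This rests on only one pair of compounds per core, so it does not show that the gain would appear on any further core or at other chain lengths, and since each number comes from a single concentration, it says nothing about potency.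

The compounds shown leave open what a still longer chain would do on either core, and whether the gain would continue or level off. As far as these compounds go, they also leave open what would happen if an amine or a carboxylic acid took the place of the isothiocyanate at the end of the chain, so the part this end group plays in the numbers remains unknown.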